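Difluorophenyl in place of methoxyphenyl on the benzyl arm

A few compounds are considered here, and "the series" means these few. Any claim that something is new, unique, unknown or untested is made for them only; others in the source may bear on it.

Measured compounds:
- compound 1, `O=C(O)c1ccccc1-c1ccc(CCc2ncc(Cc3ccccc3F)[nH]2)cc1`: 9.5 nM
- compound 2, `O=C(O)c1ccccc1-c1ccc(CCc2ncc(Cc3cccc(Cl)c3)[nH]2)cc1`: 31 nM
- compound 3, `COc1cccc(Cc2cnc(CCc3ccc(-c4ccccc4C(=O)O)cc3)[nH]2)c1`: 79 nM

All three share one core and differ only in the group carried on a saturated chain carbon bound to an aromatic carbon. In an in vitro functional assay on cells for agonist activity at Bombesin receptor subtype-3 (Mus musculus), read by luminescence and calcium flux (on this read-out higher numbers stand for an effect only at larger amounts of compound and lower numbers for an effect already at smaller amounts), compound 3 gives 79 nM, the highest number of the three: the nearest is compound 2, reached by a 2.5-fold higher number from compound 2 to compound 3 (0.41 log units; beyond the scatter), and the furthest is compound 1, reached by an 8.3-fold higher number from compound 1 to compound 3 (0.92 log units; beyond the scatter). So among these, a fluorine sitting as in 2-fluorophenyl goes with the lowest numbers seen.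

The next compound, compound 4, `O=C(O)c1ccccc1-c1ccc(CCc2ncc(Cc3cccc(F)c3F)[nH]2)cc1`, carries the change (2,3-difluorophenyl in place of 3-methoxyphenyl on a saturated chain carbon bound to an aromatic carbon). It combines the 2-fluorophenyl pattern of compound 1 with a second fluorine at the place of the methoxy in compound 3. Within the data shown here, the steps that bear on this are an 8.3-fold higher number from compound 1 to compound 3 (0.92 log units; beyond the scatter) and a 2.5-fold higher number from compound 2 to compound 3 (0.41 log units; beyond the scatter), both pointing to smaller numbers when the methoxyphenyl is removed. A lower number is therefore expected for compound 4 in this assay, by an estimated step of a 5.3-fold lower number from compound 3 to compound 4 (0.72 log units; beyond the scatter), though whether the second fluorine adds anything beyond the scatter cannot be told from these three compounds alone. Compound 4 is estimated at 15 nM, between 5 nM and 45 nM.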

Compound 4, half-maximal effective concentration: 8 nM
Beside the measured number, compound 4's estimate is 1.9-fold (0.27 log units) above it, within the range that was stated.
By their numbers in this assay, from the lowest: compounds 4 and 1 (each within the scatter of the next); then compound 2; then compound 3.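

In this assay, on a saturated chain carbon bound to an aromatic carbon, 2,3-difluorophenyl in place of 3-methoxyphenyl gives a 9.9-fold lower number from compound 3 to compound 4 (0.99 log units; beyond the scatter), the largest step in this small set. Among these compounds, the same group in place of 3-chlorophenyl gives a 3.9-fold lower number from compound 2 to compound 4 (0.59 log units; beyond the scatter), so the two fluorines are clearly better tolerated than either single group at the third ring position, and a methoxy or chloro there has no counterpart in the effect of fluorine. Fluoro in place of hydrogen on an aromatic carbon gives only a 1.2-fold lower number from compound 1 to compound 4 (0.07 log units; within the scatter), so the second fluorine makes no difference that can be told from the scatter, and the data offer no measured explanation for any of these steps.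

On these data alone, it remains open how a plain phenyl with no substituent would compare, which would show whether the fluorine shared by compound 1 and compound 4 lowers the number at all. Also open, as far as these compounds go, is whether a lone fluorine in place of the chloro of compound 2, or a trifluoromethyl or an amine on the same ring, would keep the number as low.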